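From methoxy to trifluoromethoxy on compound 1

The source may report more compounds than this note shows. Statements on the series, on what has been measured and on what is new or still open speak of the compounds shown alone.

Compound 1 `COc1ccc(-c2ncnn2-c2cc(OC)c(OC)c(OC)c2)cc1`: 360 nM
Compound 2 `COc1cccc(-c2ncnn2-c2cc(OC)c(OC)c(OC)c2)c1`: > 10000 nM (a limit)
Compound 3 `COc1cc(-c2ncnn2-c2ccc(F)cc2)cc(OC)c1OC`: > 10000 nM (a limit)

Within the data shown here, in a functional assay on MCF7 cells (Homo sapiens) for antiproliferative activity, read by MTT assay, with a stated time of 72 h (a higher number here means a weaker inhibitor, a lower number a stronger inhibitor), compound 1 gives 360 nM as the one true number here. The values of compound 2 and compound 3 are limits. Compound 4 `COc1cc(-n2ncnc2-c2ccc(OC(F)(F)F)cc2)cc(OC)c1OC` keeps the core of compound 1 and changes one group (trifluoromethyl in place of methyl on an oxygen on an aromatic ring), methoxy to trifluoromethoxy. Among the measured compounds shown here, one measured step touches that same methoxy group: shifting it cost a large amount (an at least 27-fold higher number from compound 1 to compound 2 (1.44 log units; beyond the scatter)), well beyond the scatter. That step moves the group and does not replace it, so it is only a loose guide. A moderate weakening is still expected in this assay (a 6.9-fold higher number from compound 1 to compound 4 (0.84 log units; beyond the scatter)). Compound 4 is estimated at 2500 nM (expected range 500 nM to 10000 nM).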

Compound 4, half-maximal inhibitory concentration: > 10000 nM
Compound 4: no number, only a limit; the forecaster's own chance of this, stated with the estimate: 35%; middle value at least 4.0-fold (0.60 log units) from the limit.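

In this assay, the methoxy group of compound 1 proves sensitive to replacement as well as to shifting, with an at least 27-fold higher number from compound 1 to compound 4 (1.44 log units; beyond the scatter). As far as these compounds go, compound 4 gives only a limit, not a number, so this step is a minimum and its true size stays unknown. That limit offers little to separate the weak compounds: the limit of > 10000 nM in this assay, at which 3 of the 4 values shown sit.

From the compounds shown here alone, it remains open whether any other group on this oxygen keeps the activity of compound 1. An ethyl group or a free hydroxyl there would show whether the loss extends beyond trifluoromethyl.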